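Butyl on the Ring Amine Nitrogen of Compound 2

The source may report more compounds than this note shows. Statements on the series, on what has been measured and on what is new or still open speak of the compounds shown alone.

compound 1 `O=C1c2c[n+]([O-])c3ccccc3c2C(=O)c2[nH]c3ccccc3c21`: 660 nM
compound 2 `O=C1c2c[n+]([O-])c3ccccc3c2C(=O)c2c1c1ccccc1n2CCCCN1CCNCC1`: 460 nM

Of the compounds shown here, two have been measured in a functional assay on A-375 cells (Homo sapiens) for cytotoxicity, read by MTT assay, with a stated time of 72 h; a higher number here means a weaker inhibitor, a lower number a stronger inhibitor. Compound 1 gives 660 nM, and compound 2 gives 460 nM. For the measured compounds named here, compound 2 holds one of only two numbers so far, and its gap to compound 1, a 1.4-fold lower number from compound 1 to compound 2 (0.16 log units; within the scatter), is within the scatter, so the two compounds cannot be told apart on these data.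

Compound 3 `CCCCN1CCN(CCCCn2c3c(c4ccccc42)C(=O)c2c[n+]([O-])c4ccccc4c2C3=O)CC1` is the next compound. It differs from compound 2 by butyl in place of hydrogen on an amine nitrogen in a ring. Going by the values given here, no measured step touches this part of the molecule: the single step in hand, a 1.4-fold lower number from compound 1 to compound 2 (0.16 log units; within the scatter), concerns a group entering on an aromatic nitrogen and was itself within the scatter. There is therefore no basis in the data for expecting a move in either direction, and the expected step of a 1.1-fold higher number from compound 2 to compound 3 (0.04 log units; within the scatter) is one that stays within the scatter. The estimate for compound 3 is 500 nM, expected to lie between 200 nM and 1300 nM.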

Compound 3, half-maximal inhibitory concentration: 2150 nM
Compound 3: middle estimate off by 4.3-fold (0.63 log units), on the low side; the measured number lies above the stated range.
By their numbers in this assay, from the lowest: compounds 2 and 1 (each within the scatter of the next); then compound 3.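

For the compounds shown here, in the functional assay (this assay), the amine nitrogen in the ring proves sensitive to substitution: butyl in place of hydrogen there gives a clear step (a 4.7-fold higher number from compound 2 to compound 3 (0.67 log units; beyond the scatter)), the only one of the two steps in hand that lies beyond the scatter. The earlier step (a 1.4-fold lower number from compound 1 to compound 2 (0.16 log units; within the scatter)) showed only that 4-(piperazin-1-yl)butyl could take the place of hydrogen on the aromatic nitrogen without a readable change, and it said nothing about this amine nitrogen. The new step shows that the outcome also depends on what this ring nitrogen carries, with hydrogen giving the lower number of this pair, but no measurement here bears on the reason for the move.

A single butyl group cannot show whether the number rises steadily with chain length, so methyl or a longer chain such as hexyl on the same nitrogen would be needed to define the trend. On these data alone, it also remains open whether a group carrying oxygen, such as 2-hydroxyethyl or acetyl, would behave like hydrogen or like butyl at this position.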